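Removing a methyl from compound 2

A few compounds are considered here, and "the series" means these few. Any claim that something is new, unique, unknown or untested is made for them only; others in the source may bear on it.

- compound 1 `COc1ccc(-c2cc(O)c3cccnc3n2)cc1`: 53700 nM
- compound 2 `COc1ccc(-c2cc(O)c3c(C)cc(C)nc3n2)cc1`: 91200 nM

In a functional assay on U-251 cells (Homo sapiens) (a lower number here means a stronger inhibitor of growth, a higher number a weaker inhibitor of growth), compound 2 gives 91200 nM and compound 1 gives 53700 nM. These two values lie within the usual scatter of each other, so they cannot be ranked. Compound 3 `COc1ccc(-c2cc(O)c3ccc(C)nc3n2)cc1` is compound 2 with hydrogen in place of methyl on an aromatic carbon, opposite the ring nitrogen (hydrogen in place of methyl on an aromatic carbon).

For the measured compounds named here, no step involving a change in only one place has been measured. Going by the values given here, the only guide is that compound 2, which carries methyl groups that compound 1 lacks, stays within the scatter of compound 1 in this assay. No change beyond the scatter is therefore expected, and the estimated step is a 1.3-fold lower number from compound 2 to compound 3 (0.11 log units; within the scatter). For compound 3, the expected value is 70000 nM, with an estimated range of 35000 nM to 130000 nM.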

Compound 3, concentration for 50% growth inhibition: > 100000 nM
Compound 3 gave a limit, no number; the forecaster's own chance of this, stated with the estimate: 15%; middle value at least 1.4-fold (0.15 log units) away from the limit.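

In this assay compound 3 gives > 100000 nM, which is a limit of the assay and not a number. Putting hydrogen in place of the methyl opposite the ring nitrogen gives an at least 1.0-fold higher number from compound 2 to compound 3 (0.04 log units; that floor lies within the scatter), while adding a methyl on an aromatic carbon of compound 1 gives an at least 1.8-fold higher number from compound 1 to compound 3 (0.27 log units; that floor lies within the scatter), so both steps are floors and neither shows a real change. What is new is the first reading of a change in only one place, and at this position hydrogen in place of methyl brings no sign of stronger growth inhibition, with the result resting on a limit: the limit of > 100000 nM in this assay, at which 1 of the 3 values shown sits.

On these data alone, the true size of both steps stays unknown. As far as these compounds go, it also remains open how an amine or a carboxylic acid opposite the ring nitrogen would behave in this assay.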